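This account rests on a few compounds, and the source may have more. Where it says the series, first, only, none or still open, it means among the compounds named here.

Compound 1 `COc1ccc(CN(C(=O)C2CC2)c2cc(OC)c(OC)c(OC)c2)cc1O` gives 49 nM in a functional assay on HCT-116 cells (Homo sapiens) for inhibition, read by MTT assay, with a stated time of 48 h; a lower number here means a stronger inhibitor, a higher number a weaker inhibitor.
Compound 2 `COc1ccc(CNc2cc(OC)c(OC)c(OC)c2)cc1Br` gives 48100 nM in this assay.
Compound 3 `COc1cc(NCc2ccccc2)cc(OC)c1OC` gives > 80000 nM in this assay, which is a limit of the assay and not a number.

Of the two numbers shown, compound 1 has the lowest, and compound 2, its nearest neighbour, lies far higher, well beyond the scatter of repeated measurements. Compound 3 sits at the limit of > 80000 nM in this assay, at which 1 of the 3 values shown sits. Compounds 2 and 3 each carry a free amine link and lack the acyl group of compound 1, and their values are the two weakest seen; with no single-point steps between them, the data show only this contrast, not its cause.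

Compound 4 `COc1ccc(CN(C(=O)CN=[N+]=[N-])c2cc(OC)c(OC)c(OC)c2)cc1O` has not yet been measured in this assay. It differs from compound 1 in one place: azidomethyl in place of cyclopropyl on a carbonyl carbon. The exchange keeps the acyl amide of compound 1 and alters only the group on the carbonyl carbon, whose other neighbour is the amide-type nitrogen. For the measured compounds named here, no measured step covers such an exchange, so the expectation rests on compound 1 alone; a small step in this assay, towards a somewhat higher number, is expected, possibly within the scatter. Compound 4 is therefore expected to give about 120 nM in this assay, with a range from 30 nM to 500 nM. This amounts to an expected step of a 2.4-fold higher number from compound 1 to compound 4 (0.39 log units; beyond the scatter).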

Compound 4, half-maximal inhibitory concentration: 410 nM
Beside the measured number, compound 4's estimate is 3.4-fold (0.53 log units) below it, within the range that was stated.
By their numbers in this assay, from the lowest: compound 1; then compound 4; then compound 2. At a limit, above all of these: compound 3.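

For the compounds shown here, the group on the carbonyl carbon is the first place where a single exchange can be read, and in this assay it matters: azidomethyl in place of cyclopropyl gives an 8.4-fold higher number from compound 1 to compound 4 (0.92 log units; beyond the scatter) on the shared core, so the number at this position responds to what is attached there. Even so, compound 4 gives 410 nM with a group that has no ring and carries nitrogen, which shows that the three-membered carbon ring of compound 1 is not a strict requirement for a number of this order, though ring, size and atom types all change together in this one step. Nothing measured here gives a property of either group that would account for the step.

On these data alone, whether the loss follows from opening the ring or from the azide itself stays open, and a plain methyl, a cyclobutyl or an aminomethyl on the same carbonyl carbon would begin to separate the two. The compounds shown also hold no single exchange that removes the whole acyl group from compound 1 and leaves the rest in place, so what the carbonyl itself contributes remains unread.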